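Methyl for methoxy on the chloro-bearing core

The source may hold more compounds than are shown below. What is called first, only, known or untested is meant among the compounds shown, and "the series" means these compounds.

Measured compounds:
compound 1 `COc1ccc(C2=NN(C(=O)CN3CCCCC3)C(c3ccccc3O)C2)cc1`: 12700 nM
compound 2 `Cc1ccc(C2=NN(C(=O)CN3CCCCC3)C(c3ccccc3O)C2)cc1`: 11300 nM
compound 3 `COc1ccc(C2=NN(C(=O)CN3CCCCC3)C(c3cc(Cl)ccc3O)C2)cc1`: 9650 nM

In an assay on isolated protein for inhibition of Amine oxidase [flavin-containing] A (Homo sapiens), read by fluorescence, with stated times of 15 min and 20 min (a higher number here means a weaker inhibitor, a lower number a stronger inhibitor), compound 1 gives 12700 nM, compound 2 gives 11300 nM and compound 3 gives 9650 nM. The change from compound 1 to compound 2 is methyl in place of methoxy on an aromatic carbon and gave a 1.1-fold lower number from compound 1 to compound 2 (0.05 log units; within the scatter). The core of compound 3 differs from the core of compound 1 by chloro in place of hydrogen on an aromatic carbon, a step of a 1.3-fold lower number from compound 1 to compound 3 (0.12 log units; within the scatter). Compound 4 `Cc1ccc(C2=NN(C(=O)CN3CCCCC3)C(c3cc(Cl)ccc3O)C2)cc1` carries the same change on the core of compound 3: methyl in place of methoxy on an aromatic carbon; the place matches word for word, so it is the same change. The step from compound 3 to compound 4 is expected to be a 1.1-fold lower number from compound 3 to compound 4 (0.04 log units; within the scatter), because a 1.1-fold lower number from compound 1 to compound 2 (0.05 log units; within the scatter) was within the scatter. Compound 4 is therefore estimated at 8800 nM, between 4500 nM and 17000 nM.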

Compound 4, half-maximal inhibitory concentration: 14400 nM
For compound 4 the middle estimate is 1.6-fold (0.21 log units) below the measured one; the measured number falls inside the stated range.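

In this assay, methyl in place of methoxy on the core of compound 3 gives a 1.5-fold higher number from compound 3 to compound 4 (0.17 log units; within the scatter), and the two cores do not differ for this change: the same change on two cores in this assay, a 1.1-fold lower number (0.05 log units; within the scatter) from compound 1 to compound 2 and a 1.5-fold higher number (0.17 log units; within the scatter) from compound 3 to compound 4, 1.7-fold (0.22 log units) apart, within the scatter of two such steps

Chloro in place of hydrogen, read on the core of compound 2, gives a 1.3-fold higher number from compound 2 to compound 4 (0.11 log units; within the scatter), and again the two cores do not differ: the same change on two cores in this assay, a 1.3-fold lower number (0.12 log units; within the scatter) from compound 1 to compound 3 and a 1.3-fold higher number (0.11 log units; within the scatter) from compound 2 to compound 4, 1.7-fold (0.22 log units) apart, within the scatter of two such steps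

All of these steps lie within the scatter, so they show that neither change gave a measurable step on either core, but they do not test whether a step of real size would carry from one core to another.

Left open is whether an amine, a carboxylic acid or a longer chain in place of the methoxy would give a step beyond the scatter. Also open, as far as these compounds go, is whether such a step would hold on both the core of compound 1 and the core of compound 3.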